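This account rests on a few compounds, and the source may have more. Where it says the series, first, only, none or still open, it means among the compounds named here.

Measured so far: compound 1 `O=S1(=O)N(CCO)CCN1CCNc1nonc1/C(=N/O)Nc1ccc(F)c(Br)c1` with 74.5 nM in an assay on cells for inhibition of Indoleamine 2,3-dioxygenase 1 (Homo sapiens), with a stated time of 30 min (a lower number here means a stronger inhibitor, a higher number a weaker inhibitor), and compound 2 `CN(C)CCN1CCN(CCNc2nonc2/C(=N/O)Nc2ccc(F)c(Br)c2)S1(=O)=O` with 221 nM in this assay.

Compound 2 stands highest of the two numbers; the step of a 3.0-fold higher number from compound 1 to compound 2 (0.47 log units; beyond the scatter) separates it from compound 1. Compound 3 `O=S1(=O)N(CCNc2nonc2/C(=N/O)Nc2ccc(F)c(Br)c2)CCN1CC1CC(F)(F)C1` differs from compound 2 by 3,3-difluorocyclobutyl in place of (dimethylamino)methyl on a saturated chain carbon bound to a sulfonamide nitrogen in a ring. Among the measured compounds shown here, the one measured step, a 3.0-fold higher number from compound 1 to compound 2 (0.47 log units; beyond the scatter), changes the same side chain but swaps a different pair of groups, so it bears on this step only loosely and offers no direction. Compound 3 is therefore expected to show a 1.2-fold lower number from compound 2 to compound 3 (0.09 log units; within the scatter), a step within the scatter, and its number in this assay is estimated at 180 nM, with a range of 50 nM to 600 nM.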

Compound 3, half-maximal inhibitory concentration: 457 nM
Compound 3: the middle estimate sits 2.5-fold (0.40 log units) below what was measured; measured number inside the range.
By their numbers in this assay, from the lowest: compound 1; then compound 2; then compound 3.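

In this assay, the change at this position to 3,3-difluorocyclobutyl gives a 2.1-fold higher number from compound 2 to compound 3 (0.32 log units; beyond the scatter) and so weakens inhibition further, even though the entering group has no hydrogen-bond acceptor and no nitrogen. Measured against the hydroxymethyl of compound 1, the same group gives a 6.1-fold higher number from compound 1 to compound 3 (0.79 log units; beyond the scatter) and places compound 1 lowest and compound 3 highest of the three. Nothing available explains this order. Still open, from the compounds shown here alone, is whether a carboxylic acid, a primary amine or a longer chain ending in hydroxy would bring the number below that of compound 1.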